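The source may hold more compounds than are shown below. What is called first, only, known or untested is meant among the compounds shown, and "the series" means these compounds.

The shared core appears in compound 1 `O=C(Nc1ccc(S(=O)(=O)N2CCN(c3ccc(F)cc3)CC2)cc1)C1C(C(=O)O)[C@H]2CC[C@@H]1O2`, compound 2 `O=C(Nc1ccc(S(=O)(=O)NC2CCCCC2)cc1)C1C(C(=O)O)[C@H]2CC[C@@H]1O2` and compound 3 `CCOC(=O)Cc1csc(NC(=O)C2C(C(=O)O)[C@H]3CC[C@@H]2O3)n1`. In an ADME assay on WI-38 cells (Homo sapiens) for cytotoxicity, read by MTT assay, with a stated time of 48 h (on this read-out lower numbers stand for stronger inhibition and higher numbers for weaker inhibition), compound 1 gives 50200 nM. In this assay compound 2 gives 62500 nM, and the gap between compound 2 and compound 1 lies within the scatter of repeated measurements, so the two cannot be told apart on this read-out. For compound 3 in this assay only a limit is recorded, > 100000 nM. That entry is one of the values sitting at the limit of > 100000 nM in this assay, at which 1 of the 3 values shown sits. Compound 2 thus stands beside compound 1, with nothing in the numbers shown to separate them.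

Compound 4 `O=C(Nc1ccc(S(=O)(=O)NC2CC2)cc1)C1C(C(=O)O)[C@H]2CC[C@@H]1O2` has not yet been measured in this assay. It differs from compound 2 in one place: cyclopropyl in place of cyclohexyl on a sulfonamide nitrogen, the same difference read one bond further out being cyclohexylamino to cyclopropylamino. Among the compounds with values here, no measured pair in the set carries this change, so there is no step to lean on. The number for compound 4 in this assay is expected to sit at or somewhat above that of compound 2, with any movement likely small against the scatter. The step expected here is a 1.3-fold higher number from compound 2 to compound 4 (0.11 log units; within the scatter). Compound 4 in this assay is estimated at 80000 nM, within a range from 35000 nM to 180000 nM.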

Compound 4, half-maximal inhibitory concentration: 52100 nM
Compound 4: middle estimate off by 1.5-fold (0.19 log units), on the high side; low and high end bracket the measured number.
By their numbers in this assay, from the lowest: compounds 1, 4 and 2 (each within the scatter of the next). At a limit, above all of these: compound 3.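

In this assay, the change of cyclohexyl to cyclopropyl on a sulfonamide nitrogen gives a 1.2-fold lower number from compound 2 to compound 4 (0.08 log units; within the scatter). Within the data shown here, this is the first step the set offers at this position, since the earlier compounds held no pair differing in one place. It shows that going from a six-membered ring of 6 heavy atoms to a three-membered ring of 3 heavy atoms leaves the number within the scatter, so on this read-out the two groups cannot be told apart, and no measured property shown here bears on this result.

What the compounds shown leave open is whether this insensitivity reaches beyond these two carbon rings, for instance to a bare sulfonamide with two hydrogens on the nitrogen, a longer chain such as n-hexyl, or a chain ending in an amine or a carboxylic acid. One step with two rings also cannot say whether any group at this position would move the number beyond the scatter in this assay, so no trend in ring size can be drawn from this pair alone.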